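Changing the group on the amide nitrogen of compound 1

A few compounds are considered here, and "the series" means these few. Any claim that something is new, unique, unknown or untested is made for them only; others in the source may bear on it.

Compound 1 `COc1ccc(C(=O)Nc2ccccc2SC)cc1OC1CCCC1` stands second highest of three numbers in an assay on isolated protein for inhibition of phosphodiesterase 4A (Sus scrofa) (a lower number here means a stronger inhibitor, a higher number a weaker inhibitor), where compound 1 gives 1200 nM. Compound 2 `COc1ccc(C(=O)Nc2ccccc2C(=O)c2ccccc2)cc1OC1CCCC1` gives 1700 nM, and the step of a 1.4-fold higher number from compound 1 to compound 2 (0.15 log units; within the scatter). Compound 3 `COc1ccc(C(=O)Nc2c(F)c(F)nc(F)c2F)cc1OC1CCCC1` gives 550 nM, a number beyond the scatter from that of compound 1 and the lowest of the three. Compound 4 `COc1ccc(C(=O)Nc2c(C)nsc2Br)cc1OC1CCCC1` differs from compound 1 in one place: 5-bromo-3-methyl-1,2-thiazol-4-yl in place of 2-(methylsulfanyl)phenyl on an amide-type nitrogen. Within the data shown here, no measured step covers this change directly; the one single-place step available lies within the scatter, while compound 3, which also carries a ring with hetero atoms on the amide nitrogen, shows the lowest number. The step from compound 1 to compound 4 is therefore expected to be a 1.6-fold lower number from compound 1 to compound 4 (0.20 log units; within the scatter), a modestly lower number. Compound 4 is estimated at 750 nM, between 300 nM and 1900 nM.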

Compound 4, half-maximal inhibitory concentration: 500 nM
For compound 4 the middle estimate is 1.5-fold (0.18 log units) above the measured one, and the stated range covers the measured number.
By their numbers in this assay, from the lowest: compounds 4 and 3 (each within the scatter of the next); then compounds 1 and 2 (each within the scatter of the next).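

In this assay, among these compounds, changing the ring on the amide nitrogen gives a 2.4-fold lower number from compound 1 to compound 4 (0.38 log units; beyond the scatter), the first single-place step in this set to leave the scatter. Compound 4 and compound 3 stand within the scatter of each other, so two different rings with hetero atoms reach a similar level on this nitrogen. Nothing in the data gives a reason for the step. The compounds shown leave open whether the bromine, the methyl or the ring itself carries the step, and how a ring bearing an amine or a carboxylic acid in place of the bromine would read.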